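The source may report more compounds than this note shows. Statements on the series, on what has been measured and on what is new or still open speak of the compounds shown alone.

In a functional assay on Hep 3B2 cells (Homo sapiens) for antiproliferative activity, read by MTT assay, with a stated time of 24 h, tested at 0.01 ug/mL (on this read-out higher numbers stand for a stronger effect at the one concentration tested and lower numbers for a weaker effect), compound 1 `Cc1ccc2nc(C(=O)Nc3c(F)cc(-c4cccc(F)c4)cc3F)c(C)c(O)c2c1` gives 0.22% and compound 2 `Cc1ccc2nc(C(=O)Nc3c(F)cc(-c4cccc(F)c4)cc3F)c(C)c(C(=O)O)c2c1` gives 0.36%. Compound 2 stands as the higher of the two numbers shown, but the only measured step, a number 0.1 percentage points higher from compound 1 to compound 2 (within the scatter), lies within the scatter, so the two compounds cannot be told apart on this read-out. Compound 3 `Cc1c(C(=O)Nc2c(F)cc(-c3cccc(F)c3)cc2F)nc2ccc(F)cc2c1C(=O)O` follows from compound 2 by the change (fluoro in place of methyl on an aromatic carbon), sited on the six-membered aromatic ring of carbon only within the fused system of the shared core, the carboxy retained. Within the data shown here, no measured step touches this site: the one step recorded, carboxy in place of hydroxy, moved nothing beyond the scatter, and no exchange of methyl for fluoro has been measured anywhere. Both measured numbers sit close to zero in this assay, which points to no movement beyond the scatter for compound 3. The expected step is therefore a number 0.1 percentage points lower from compound 2 to compound 3 (within the scatter). Compound 3 is estimated at 0.3%, with a range from -6% to 7%.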

Compound 3, a percentage reported as inhibition, at one concentration (the size of the read-out at that concentration, not a potency): -0.35%
Compound 3: middle estimate off by 0.7 percentage points, on the high side; measured number inside the range.
By their numbers in this assay, from the lowest: compounds 3, 1 and 2 (each within the scatter of the next).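

In this assay, among these compounds, the change to fluoro in place of methyl on an aromatic carbon, with the carboxy retained, gives a number 0.7 percentage points lower from compound 2 to compound 3 (within the scatter) and so provides the first reading at this position, on the six-membered aromatic ring of carbon only. This reading shows no separation between methyl and fluoro here on this read-out, at the one concentration tested. Neither single change now recorded, this one or carboxy in place of hydroxy, moves the number beyond the scatter.

Going by these compounds, whether a larger group at this position, such as an amine, a methoxy or a longer chain, would move the number remains open. Also open, on these data alone, is how methyl and fluoro compare under conditions where the numbers stand clear of zero. Nothing available bears on a cause for this result.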